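Replacing the bicyclic amine in compound 1 with 4-methylpiperazine

The source may report more compounds than this note shows. Statements on the series, on what has been measured and on what is new or still open speak of the compounds shown alone.

Of the compounds shown here, three sharing one core have been measured in a functional assay on A-375 cells (Homo sapiens) for antiproliferative activity, read by CCK-8 assay, with a stated time of 72 h, tested at 2 uM; a lower number here means a weaker effect, a higher number a stronger effect of the compound at the concentration tested. Compound 1 `Nc1ccccc1NC(=O)c1ccc(CSC(=S)N2CCCc3ccccc32)cc1` gives 26.5% and stands lowest of the three numbers. Among the compounds with values here, its nearest neighbour is compound 3 `Nc1ccccc1NC(=O)c1ccc(CSC(=S)N2CCc3cc(Cl)ccc32)cc1`, with 31.9%, and the only step computed between two measured compounds is a number 5.4 percentage points higher from compound 1 to compound 3 (within the scatter). Within the data shown here, the furthest is compound 2 `Nc1ccccc1NC(=O)c1ccc(CSC(=S)N2CCN(c3ccncc3)CC2)cc1`, which gives 85.7%; no single-place step is drawn between compound 1 and compound 2, so their two values can only be set side by side.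

Compound 4 `CN1CCN(C(=S)SCc2ccc(C(=O)Nc3ccccc3N)cc2)CC1` has not yet been measured. Relative to compound 1 the change is 4-methylpiperazin-1-yl in place of 1,2,3,4-tetrahydroquinolin-1-yl on a thiocarbonyl carbon. Among the measured compounds shown here, no measured step follows this exact exchange. The step from compound 1 to compound 3 swaps one bicyclic amine for another and stays within the scatter, so it says little about moving to a single saturated ring with two heteroatoms. The value of compound 2, which also carries a piperazine on the thiocarbonyl carbon and reads 85.7%, is the closest guide and points upward.

Compound 4 is therefore expected to rise beyond the scatter, with an estimated step of a number 31.5 percentage points higher from compound 1 to compound 4 (beyond the scatter). The expected value of compound 4 in this assay is 58%, within a range from 30% to 85%.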

Compound 4, a percentage reported as inhibition, at one concentration (the size of the read-out at that concentration, not a potency): 36.6%
Beside the measured number, compound 4's estimate is 21.4 percentage points above it; measured number inside the range.
By their numbers in this assay, from the lowest: compounds 1, 3 and 4 (each within the scatter of the next, the first and the last beyond it); then compound 2.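

The piperazine ring on the thiocarbonyl carbon does not by itself carry the high reading of compound 2: with methyl in place of pyridin-4-yl on an amine nitrogen in a ring, this assay shows a number 49.1 percentage points lower from compound 2 to compound 4 (beyond the scatter), a large loss from one change at a single substituent. Against the bicyclic amines the gain is small, with a number 10.1 percentage points higher from compound 1 to compound 4 (beyond the scatter), only a modest step, and a number 4.7 percentage points higher from compound 3 to compound 4 (within the scatter), which does not separate those two compounds. At this position, then, the substituent on the piperazine nitrogen matters far more in this set than the exchange of either bicyclic amine for 4-methylpiperazin-1-yl, and nothing available explains the drop from pyridin-4-yl to methyl.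

The compounds shown leave open whether the high reading of compound 2 depends on the ring nitrogen of the pyridine or on any aromatic ring at that place, a question that a phenyl group on the same piperazine nitrogen would address. They also leave open how a piperazine with only hydrogen, or with an acetyl group, on that nitrogen would read.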